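Changing the Cyanoethenyl Arm of Compound 3

A few compounds are considered here, and "the series" means these few. Any claim that something is new, unique, unknown or untested is made for them only; others in the source may bear on it.

In a functional assay on NALM-6 cells (Homo sapiens) for cytotoxicity, with a stated time of 72 h (on this read-out higher numbers stand for an effect only at larger amounts of compound and lower numbers for an effect already at smaller amounts), compound 1 (`C=C[C@@](C)(/C=C/c1ccc(O)c(/C=C/C#N)c1)CCC=C(C)C`) gives > 43400 nM, which is a limit and not a number. Compound 2 (`C=C[C@@](C)(/C=C/c1ccc(O)c(/C=C/C(=O)NCc2ccc(C(F)(F)F)cc2)c1)CCC=C(C)C`) gives > 43400 nM, again a limit. For the measured compounds named here, compound 3 (`COc1ccc(/C=C/[C@@](C)(/C=C/c2ccc(O)c(/C=C/C#N)c2)CCC=C(C)C)cc1`) gives 16500 nM, the only true number among the three. Placing 2-(4-methoxyphenyl)ethenyl in place of vinyl produced an at least 2.6-fold lower number from compound 1 to compound 3 (0.42 log units; beyond the scatter).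

Compound 4 (`CCOC(=O)/C(C)=C/c1cc(/C=C/[C@](C)(/C=C/c2ccc(OC)cc2)CCC=C(C)C)ccc1O`) now carries 2-(ethoxycarbonyl)prop-1-en-1-yl in place of 2-cyanoethenyl on an aromatic carbon, ortho to a hydroxy group: 2-(ethoxycarbonyl)prop-1-en-1-yl in place of 2-cyanoethenyl on an aromatic carbon. Going by the values given here, the one measured step lies at a different place in the molecule, so it offers only indirect guidance. Compound 1 and compound 2 both rest on (the limit of > 43400 nM in this assay, at which 2 of the 3 values shown sit), so together they give no size for a change at this arm. Among the compounds with values here, with no measured step at this place, no step beyond the scatter is expected in this assay. The expected step is a 1.0-fold lower number from compound 3 to compound 4 (0.01 log units; within the scatter). The estimated value for compound 4 is 16000 nM, with an expected range from 5000 nM to 43000 nM.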

Compound 4, half-maximal effective concentration: > 43400 nM
Compound 4: only a limit was reported (the forecaster's own chance of this, stated with the estimate: 20%); at least 2.7-fold (0.43 log units) between middle value and limit.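

For the compounds shown here, changing the arm from 2-cyanoethenyl to 2-(ethoxycarbonyl)prop-1-en-1-yl, on the aromatic carbon ortho to a hydroxy group, gives in this assay an at least 2.6-fold higher number from compound 3 to compound 4 (0.42 log units; beyond the scatter), the first reading at this position and a step beyond the scatter. Compound 4 gives > 43400 nM, which is a limit and not a number, so the step has a minimum size but no full size. The single measured value in the set therefore depends on the arm as well as on the 2-(4-methoxyphenyl)ethenyl group, and the limit now covers most of the compounds shown: the limit of > 43400 nM in this assay, at which 3 of the 4 values shown sit.

The compounds shown do not separate the ethoxycarbonyl group from the added methyl branch on the arm. On these data alone, it also remains open whether a carboxylic acid or a primary amide at this position would keep a measurable value in this assay.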